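Piperidinone fumaramide series: anilide change

This account rests on a few compounds, and the source may have more. Where it says the series, first, only, none or still open, it means among the compounds named here.

Measured so far:
compound 1 `COc1ccc(NC(=O)/C=C/C(=O)N2C/C(=C\c3ccc([N+](=O)[O-])cc3)C(=O)/C(=C/c3ccc([N+](=O)[O-])cc3)C2)cc1` — 940 nM
compound 2 `O=C(/C=C/C(=O)N1C/C(=C\c2ccccc2)C(=O)/C(=C/c2ccccc2)C1)Nc1ccc(Cl)c(Cl)c1` — 1700 nM

In a functional assay on Molt4/C8 cells (Homo sapiens) for cytotoxicity (a lower number here means a stronger inhibitor, a higher number a weaker inhibitor), compound 1 gives 940 nM and compound 2 gives 1700 nM; the two numbers lie within the usual scatter of each other, so no order can be read from them. Compound 3 `O=C(/C=C/C(=O)N1C/C(=C\c2ccccc2)C(=O)/C(=C/c2ccccc2)C1)Nc1ccc([N+](=O)[O-])cc1` keeps the core of compound 2 and differs in one place: 4-nitrophenyl in place of 3,4-dichlorophenyl on an amide-type nitrogen. No step for this change is shown among the measured compounds. The step of a 1.2-fold lower number from compound 2 to compound 3 (0.08 log units; within the scatter) is expected to remain within the scatter, with no direction called. For compound 3 the estimated value in this assay is 1400 nM, range 500 nM to 4000 nM.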

Compound 3, half-maximal inhibitory concentration: 31000 nM
Beside the measured number, compound 3's estimate is 22-fold (1.35 log units) below it, and the stated range ends below it.
By their numbers in this assay, from the lowest: compounds 1 and 2 (each within the scatter of the next); then compound 3.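

In this assay the group on the amide-type nitrogen is not a silent position: with the shared core unchanged, 4-nitrophenyl in place of 3,4-dichlorophenyl gives an 18-fold higher number from compound 2 to compound 3 (1.26 log units; beyond the scatter) and a clear loss of potency. Within the data shown here, this is the first single-place step, and it shows that the number can respond strongly to this exchange. No measurement shown bears on the reason for the step. On these data alone, it remains open whether the loss tracks the entering nitro group or the departing chlorines; 4-chlorophenyl or 4-aminophenyl on the same nitrogen would help separate the two.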